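This account rests on a few compounds, and the source may have more. Where it says the series, first, only, none or still open, it means among the compounds named here.

Measured so far in a functional assay on the whole organism with Rattus norvegicus as the target; a lower number here means that less compound is needed, a higher number that more compound is needed for the effect:
compound 1 `CC1CCC(=NNc2ccccc2)c2ncc(C(=O)O)c(=O)n21` gives 0.6 umol/kg;
compound 2 `CC1CCC(=NNc2ccccc2C(=O)O)c2ncc(C(=O)O)c(=O)n21` gives 0.48 umol/kg;
compound 3 `CC1CCC(C)(N=Nc2ccccc2)c2ncc(C(=O)O)c(=O)n21` gives 35 umol/kg.

Compound 2 differs from compound 1 by one change, (carboxy in place of hydrogen on an aromatic carbon), and this change made the step of a 1.3-fold lower number from compound 1 to compound 2 (0.10 log units; within the scatter). Compound 4 `CC1CCC(C)(N=Nc2ccccc2C(=O)O)c2ncc(C(=O)O)c(=O)n21` is not yet measured; it differs from compound 3 by the same change, (carboxy in place of hydrogen on an aromatic carbon), at the same kind of place. The difference between the core of compound 3 and the core of compound 1 is not broken down here; their values show that compound 3 needs far more compound than compound 1 does. Because the earlier step of a 1.3-fold lower number from compound 1 to compound 2 (0.10 log units; within the scatter) stayed within the scatter, the step from compound 3 to compound 4 is expected to be small as well, about a 1.3-fold lower number from compound 3 to compound 4 (0.10 log units; within the scatter). On that basis compound 4 is estimated to give 28 umol/kg in this assay, between 12 umol/kg and 70 umol/kg.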

Compound 4, dose for 50% inhibition: > 100 umol/kg
Compound 4 ended at the assay's limit (the forecaster's own chance of this, stated with the estimate: 10%); middle value at least 3.5-fold (0.55 log units) from the limit.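

On the core of compound 3, carboxy in place of hydrogen on an aromatic carbon gave an at least 2.8-fold higher number from compound 3 to compound 4 (0.45 log units; beyond the scatter) in this assay. The change therefore did not carry over unchanged from the core of compound 1 to the core of compound 3: the same change on two cores in this assay, a 1.3-fold lower number (0.10 log units; within the scatter) from compound 1 to compound 2 and an at least 2.8-fold higher number (0.45 log units; beyond the scatter) from compound 3 to compound 4, at least 3.5-fold (0.55 log units) apart, beyond the scatter of two such steps

The value of compound 4 is a limit and not a number, so this does not show how large the step really is, nor, with only two pairs, how the change behaves on any other core: the limit of > 100 umol/kg in this assay, at which 1 of the 4 values shown sits.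

The compounds shown leave open whether another group in the same place, such as an amine or a nitrile, would also differ between the two cores. They also leave open which feature of the core of compound 3 goes with the different outcome.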